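The source may hold more compounds than are shown below. What is called first, only, known or untested is meant among the compounds shown, and "the series" means these compounds.

Measured in a functional assay on HCT-15 cells (Homo sapiens) for antiproliferative activity, read by MTT assay, with a stated time of 72 h; a lower number here means a stronger inhibitor, a higher number a weaker inhibitor:
- Compound 1 `CCCn1ccnc1-c1cc(OC)c(OC)c(OC)c1` gives > 100000 nM, which is a limit and not a number.
- Compound 2 `COc1cc(-c2nccn2C(C)C)cc(OC)c1OC` gives > 100000 nM, which is also a limit.
- Compound 3 `COc1cc(-c2nccn2-c2ccc(F)cc2)cc(OC)c1OC` gives 68600 nM.

For the measured compounds named here, compound 3 holds the only true number in this small set, and the rest of the picture is the limit of > 100000 nM in this assay, at which 2 of the 3 values shown sit. Compound 4 `COc1ccc(-n2ccnc2-c2cc(OC)c(OC)c(OC)c2)cc1` has not yet been measured. It replaces the 4-fluorophenyl of compound 3 with 4-methoxyphenyl, so that methoxy stands in place of fluoro on an aromatic carbon, para to a large group: methoxy in place of fluoro on an aromatic carbon.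

Going by the values given here, only two measured steps reach compound 3. The first is an at least 1.4-fold lower number from compound 1 to compound 3 (0.16 log units; that floor lies within the scatter) and the second is an at least 1.4-fold lower number from compound 2 to compound 3 (0.16 log units; that floor lies within the scatter). Both change the group on the aromatic nitrogen, and neither tests the new substitution directly. The step that the two limits leave unreadable from compound 1 to compound 2 adds nothing further. The data therefore give no reason to expect a real shift in this assay. The expected change is a 1.4-fold lower number from compound 3 to compound 4 (0.14 log units; within the scatter), which would not go beyond the scatter. For compound 4 the estimated value is 50000 nM, with an expected range from 15000 nM to 100000 nM.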

Compound 4, half-maximal inhibitory concentration: 1300 nM
Beside the measured number, compound 4's estimate is 38-fold (1.59 log units) above it; measured number below the stated range.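

In this assay, for the compounds shown here, the place para to a large group on the aromatic ring proves highly sensitive, with methoxy in place of fluoro giving a 53-fold lower number from compound 3 to compound 4 (1.72 log units; beyond the scatter), whereas the earlier compounds changed only the group on the aromatic nitrogen. That group now also shows a large effect, with 4-methoxyphenyl giving an at least 76-fold lower number from compound 2 to compound 4 (1.88 log units; beyond the scatter) and an at least 76-fold lower number from compound 1 to compound 4 (1.88 log units; beyond the scatter), while 4-fluorophenyl had shown only floors within the scatter. These two new steps are also floors, and their starting values are limits and not numbers: the limit of > 100000 nM in this assay, at which 2 of the 4 values shown sit.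

The compounds shown carry only fluoro and methoxy at this place, so they do not tell whether a hydroxyl, an amine or an ethoxy group would match methoxy. They also leave open whether the step follows the oxygen itself or the added carbon.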